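This account rests on a few compounds, and the source may have more. Where it says the series, first, only, none or still open, it means among the compounds named here.

Compound 1 `Clc1ccc2[nH]cc(SC3CCNCC3)c2c1`: 1.2 mg/kg
Compound 2 `Cc1[nH]c2ccc(Cl)cc2c1SC1CCNCC1`: 9.9 mg/kg

In a functional assay on the whole organism with Mus musculus as the target, in the hot plate test (on this read-out lower numbers stand for an effect already at smaller amounts and higher numbers for an effect only at larger amounts of compound), compound 1 gives 1.2 mg/kg, the lowest of the two numbers; compound 2 stands an 8.3-fold higher number from compound 1 to compound 2 (0.92 log units; beyond the scatter). The unmeasured compound 3 `CON1CCC(Sc2c[nH]c3ccc(Cl)cc23)CC1` differs from compound 1 by methoxy in place of hydrogen on an amine nitrogen in a ring, with the oxygen-bearing group entering three ring bonds from the ring atom that bears a large group. For the measured compounds named here, the only measured step, the methyl on an aromatic carbon from compound 1 to compound 2, sits on the core and not on the amine nitrogen, so it does not bear directly on this change; no measured step involves the ring amine. Without such a precedent, the step in this assay is expected to be a moderate rise in the number, with wide uncertainty. Compound 3 is therefore estimated at 3.5 mg/kg, within 0.8 mg/kg to 15 mg/kg, which means an expected step of a 2.9-fold higher number from compound 1 to compound 3 (0.46 log units; beyond the scatter).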

Compound 3, dose for half-maximal effect: 2.3 mg/kg
Beside the measured number, compound 3's estimate is 1.5-fold (0.18 log units) above it; low and high end bracket the measured number.
By their numbers in this assay, from the lowest: compounds 1 and 3 (each within the scatter of the next); then compound 2.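

Methoxy in place of hydrogen on the amine nitrogen in a ring gives, in this assay, a 1.9-fold higher number from compound 1 to compound 3 (0.28 log units; within the scatter) and so offers the first reading at this position, which accepts a group of 2 heavy atoms without a step beyond the scatter. The earlier step, an 8.3-fold higher number from compound 1 to compound 2 (0.92 log units; beyond the scatter) and beyond the scatter, belonged to a methyl on an aromatic carbon of the core, so in these compounds the shift on the core exceeds the one on the amine nitrogen. Nothing available accounts for this result.

Going by these compounds, it remains open whether a simple methyl, a hydroxy group or a longer chain on the same amine nitrogen would stay as close to compound 1 as methoxy does. Also open, on these data alone, is how methoxy on this nitrogen would behave together with the methyl on the aromatic carbon of compound 2.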